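A few compounds are considered here, and "the series" means these few. Any claim that something is new, unique, unknown or untested is made for them only; others in the source may bear on it.

The three measured compounds, all read in an ADME assay on NCM460 cells (Homo sapiens) for cytotoxicity, read by CCK-8 assay, with a stated time of 48 h; on this read-out higher numbers stand for weaker inhibition and lower numbers for stronger inhibition:

compound 1, `COc1ccc(/C=C\c2cc(OC)c(OC)c(OC)c2)cc1OCc1ccc(CN2CCCCC2C(=O)NCCNC(=O)OC(C)(C)C)cc1`, giving 28000 nM
compound 2, `COc1ccc(/C=C\c2cc(OC)c(OC)c(OC)c2)cc1OCc1ccc(CNCCN(C)C)cc1`, giving 35000 nM
compound 3, `COc1ccc(/C=C\c2cc(OC)c(OC)c(OC)c2)cc1OCc1ccc(CN2CC[C@@H](O)C2)cc1`, giving 53000 nM

Compound 1 holds the lowest of the three numbers, yet its gaps to compound 2 and to compound 3 both fall within the usual scatter, so the three compounds cannot be told apart on this read-out. Going by the values given here, the only single-point step among them, a 1.5-fold higher number from compound 2 to compound 3 (0.18 log units; within the scatter), exchanges one amine for another at the same place and leaves the number essentially where it was.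

Compound 4, `COc1ccc(/C=C\c2cc(OC)c(OC)c(OC)c2)cc1OCc1ccc(CN2CCCCC2C(=O)NCCN)cc1`, is the unmeasured partner of compound 1. The difference is hydrogen in place of tert-butoxycarbonyl on an amine nitrogen. Among the compounds with values here, no measured pair shows this exchange: the step from compound 2 to compound 3 alters the amine that hangs from the benzylic position, not a carbamate on a distant chain nitrogen, so it offers only indirect guidance. What it does show is that reshaping this basic tail moved the number by less than the scatter. Compound 4 is therefore expected to sit close to compound 1, with a 1.1-fold higher number from compound 1 to compound 4 (0.03 log units; within the scatter) no larger than the scatter. The estimate for compound 4 is 30000 nM, with a range from 12000 nM to 75000 nM.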

Compound 4, half-maximal inhibitory concentration: > 50000 nM
Compound 4: only a limit was reported; the forecaster's own chance of this, stated with the estimate: 15%; middle value at least 1.6-fold (0.22 log units) from the limit.
By their numbers in this assay, from the lowest: compounds 1, 2 and 3 (each within the scatter of the next).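

In this assay compound 4 carries a limit and not a number, and it is the only one of the compounds shown to do so: the limit of > 50000 nM in this assay, at which 1 of the 4 values shown sits.

The earlier compounds varied only the amine on the saturated chain carbon, whereas this exchange, hydrogen in place of tert-butoxycarbonyl on an amine nitrogen, gives an at least 1.7-fold higher number from compound 1 to compound 4 (0.25 log units; that floor lies within the scatter), so the change is not shown to exceed the scatter, and how far it goes stays unknown. The larger exchange on the saturated chain carbon bound to an aromatic carbon reads the same way, with an at least 1.4-fold higher number from compound 2 to compound 4 (0.15 log units; that floor lies within the scatter), while the step between compound 3 and compound 4 cannot be read.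

Going by these compounds, the true size of the step from the carbamate to the free amine remains open, as does the question of whether any effect belongs to the free amine or to the loss of the tert-butoxycarbonyl atoms. An acetyl group on that same nitrogen, or a 3-aminopropyl chain in place of 2-aminoethyl, would be a way to probe this position further.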